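The source may hold more compounds than are shown below. What is called first, only, known or untested is meant among the compounds shown, and "the series" means these compounds.

In a functional assay on HaCaT cells (Homo sapiens) for cytotoxicity, with a stated time of 48 h (on this read-out lower numbers stand for stronger inhibition and higher numbers for weaker inhibition), two compounds have been tested so far. Compound 1 `COc1cc(O)c(C(=O)/C=C/c2ccc(F)cc2)c(OC)c1` gives > 20000 nM, which is a limit of the assay and not a number. Within the data shown here, compound 2 `COc1cc(OC)c(C(=O)/C=C/c2ccccc2OC)c(OC)c1` gives 8700 nM, the only true number available, so its standing cannot yet be judged against a second measured number.

Compound 3 `COc1cc(OC)c(C(=O)/C=C/c2ccccc2SC)c(OC)c1` has not been measured. It differs from compound 2 in one place, methylsulfanyl in place of methoxy on an aromatic carbon, ortho to a large group. Among the measured compounds shown here, no measured pair shows what this exchange does. With compound 2 at 8700 nM as the only anchor, the expectation in this assay is a step no larger than the usual scatter, with no direction favoured. The expected change is a 1.1-fold lower number from compound 2 to compound 3 (0.04 log units; within the scatter). For compound 3, the estimated value is 8000 nM, with an expected range of 3500 nM to 20000 nM.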

Compound 3, half-maximal inhibitory concentration: 7700 nM
For compound 3 the middle estimate is 1.0-fold (0.02 log units) above the measured one; the range from low to high includes it.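

Among these compounds, compound 2 and compound 3 are the first measured pair that differ in one place: in this assay, putting methylsulfanyl in place of methoxy on an aromatic carbon, ortho to a large group, gives a 1.1-fold lower number from compound 2 to compound 3 (0.05 log units; within the scatter). At this position, then, the two groups cannot be told apart on this read-out, so swapping oxygen for sulfur in this group has no visible effect here. Both compounds give true numbers, so this step can be read, unlike any comparison with a value at the limit of the assay: the limit of > 20000 nM in this assay, at which 1 of the 3 values shown sits.

Only this one exchange at this one position is shown. From the compounds shown here alone, whether a more different group here, such as an amine, a carboxylic acid or a longer chain, would move the number beyond the scatter remains open.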